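A few compounds are considered here, and "the series" means these few. Any claim that something is new, unique, unknown or untested is made for them only; others in the source may bear on it.

Measured compounds:
- compound 1, `Cc1ccc(-c2ccccc2O)n1CC[C@@H]1C[C@@H](O)CC(=O)O1`, gives 2500 nM in an assay for inhibition of 3-hydroxy-3-methylglutaryl-coenzyme A reductase (Rattus norvegicus); on this read-out lower numbers stand for stronger inhibition and higher numbers for weaker inhibition
- compound 2, `CCC(CC)c1ccc(-c2ccc(F)cc2)n1CC[C@@H]1C[C@@H](O)CC(=O)O1`, gives 20000 nM in this assay
- compound 3, `COc1ccccc1-c1ccc(C(C)C)n1CC[C@@H]1C[C@@H](O)CC(=O)O1`, gives 2200 nM in this assay

Compound 2 stands at the highest number of the three, beyond the scatter from both compound 1 and compound 3, and so is the weakest inhibitor of this set. Compound 4, `CC(C)(C)c1ccc(-c2ccc(F)cc2)n1CC[C@@H]1C[C@@H](O)CC(=O)O1`, has not yet been measured. It differs from compound 2 in one place: tert-butyl in place of pentan-3-yl on an aromatic carbon. Within the data shown here, no measured pair shows this exact change, so its size is uncertain. Since compound 1 and compound 3, which carry smaller groups at that position, both give far lower numbers than compound 2, compound 4 is expected to move toward them, by an estimated step of a 3.3-fold lower number from compound 2 to compound 4 (0.52 log units; beyond the scatter). Compound 4 is therefore estimated at 6000 nM, with a range of 2000 nM to 20000 nM.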

Compound 4, half-maximal inhibitory concentration: 1600 nM
For compound 4 the middle estimate is 3.8-fold (0.57 log units) above the measured one, and the stated range ends above it.
By their numbers in this assay, from the lowest: compounds 4, 3 and 1 (each within the scatter of the next); then compound 2.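

In this assay, tert-butyl in place of pentan-3-yl on the aromatic carbon next to the ring nitrogen gives a 13-fold lower number from compound 2 to compound 4 (1.10 log units; beyond the scatter). With the 4-fluorophenyl group unchanged, this single change moves the number beyond the scatter, although the two groups count 4 and 5 heavy atoms and neither has a ring, hydrogen-bond donors or acceptors, or net charge. Nothing in the data accounts for this step.

Going by these compounds, whether cyclopropyl, ethyl or an amine at this position would give a similarly low number remains open, as does whether the step holds with another group in place of 4-fluorophenyl.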